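A few compounds are considered here, and "the series" means these few. Any claim that something is new, unique, unknown or untested is made for them only; others in the source may bear on it.

Measured so far in an assay on isolated protein for inhibition of Amine oxidase [flavin-containing] B (Homo sapiens), read by fluorescence, with a stated time of 20 min; a lower number here means a stronger inhibitor, a higher number a weaker inhibitor:

Compound 1, `CC(C)=NNc1nc(-c2cccc([N+](=O)[O-])c2)cs1`, gives 716 nM.
Compound 2, `CCC/C(C)=N\Nc1nc(-c2cccc([N+](=O)[O-])c2)cs1`, gives 55 nM.
Compound 3, `CCCC/C(C)=N\Nc1nc(-c2cccc([N+](=O)[O-])c2)cs1`, gives 118 nM.

Compound 4, `CCCCCC/C(C)=N\Nc1nc(-c2cccc([N+](=O)[O-])c2)cs1`, is not yet measured in this assay.

The change ethyl in place of hydrogen on a saturated chain carbon bound to a carbon with a double bond to nitrogen gave a 13-fold lower number from compound 1 to compound 2 (1.11 log units; beyond the scatter). The same kind of change, (ethyl in place of hydrogen on a saturated chain carbon, four bonds along the chain from a carbon with a double bond to nitrogen), is to be made from compound 3 to compound 4; the two cores differ by propyl in place of hydrogen on a saturated chain carbon bound to a carbon with a double bond to nitrogen. The place is not the same: in the first case the carbon is bound to a carbon with a double bond to nitrogen, in the second it lies four bonds along the chain from such a carbon. Within the measured set, growth at the chain end did not help, as a 2.1-fold higher number from compound 2 to compound 3 (0.33 log units; beyond the scatter) shows, and a 6.1-fold lower number from compound 1 to compound 3 (0.78 log units; beyond the scatter) is smaller than a 13-fold lower number from compound 1 to compound 2 (1.11 log units; beyond the scatter). The expected step from compound 3 to compound 4 is therefore a 1.9-fold higher number from compound 3 to compound 4 (0.27 log units; within the scatter), set beside the earlier 13-fold lower number from compound 1 to compound 2 (1.11 log units; beyond the scatter) and resting on the direction of a 2.1-fold higher number from compound 2 to compound 3 (0.33 log units; beyond the scatter). For compound 4 the estimate in this assay is 220 nM, between 80 nM and 650 nM.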

Compound 4, half-maximal inhibitory concentration: 626 nM
The estimate for compound 4 lay 2.8-fold (0.45 log units) below the measured number; low and high end bracket the measured number.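

In this assay, adding ethyl does not carry over from one core to another, and the step even changes direction: the same change on two cores in this assay, a 13-fold lower number (1.11 log units; beyond the scatter) from compound 1 to compound 2 and a 5.3-fold higher number (0.72 log units; beyond the scatter) from compound 3 to compound 4, 69-fold (1.84 log units) apart, beyond the scatter of two such steps Adding propyl behaves the same way: the same change on two cores in this assay, a 6.1-fold lower number (0.78 log units; beyond the scatter) from compound 1 to compound 3 and an 11-fold higher number (1.06 log units; beyond the scatter) from compound 2 to compound 4, 69-fold (1.84 log units) apart, beyond the scatter of two such steps Lengthening the chain beyond that of compound 2 raises the number at each measured step, a 5.3-fold higher number from compound 3 to compound 4 (0.72 log units; beyond the scatter) and an 11-fold higher number from compound 2 to compound 4 (1.06 log units; beyond the scatter), while a 1.1-fold lower number from compound 1 to compound 4 (0.06 log units; within the scatter) leaves the two compounds within the scatter, so the gain from the first extension is lost by the chain of compound 4; this shows that the outcome of the change depends on the chain already present, but not why, and four compounds fix neither the exact chain length at which the direction turns nor a rule for other cores.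

On these data alone, whether a longer chain keeps raising the number or levels off remains open. Also open, as far as these compounds go, is whether a branched chain, or a chain ending in a hydroxyl group or an amine, follows the same course.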